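Enaminone Series: Fluoro Substitution and PC-3 Antiproliferation

The compounds below may be only part of what the source reports. "The series", "measured", "known", "first", "only" and "open" are said of these compounds alone.

compound 1 `O=C(/C=C\Nc1ccc(C(F)(F)F)cc1)c1cn(-c2ccccc2)nc1-c1ccccc1`: > 50000 nM
compound 2 `COc1cc(N/C=C\C(=O)c2cn(-c3ccccc3)nc2-c2ccccc2)cc(OC)c1OC`: 5930 nM
compound 3 `O=C(/C=C\Nc1ccc(C(F)(F)F)cc1)c1cn(-c2ccccc2)nc1-c1ccc(F)cc1`: > 50000 nM

In a functional assay on PC-3 cells (Homo sapiens) for antiproliferative activity, read by MTT assay, with a stated time of 48 h (on this read-out lower numbers stand for stronger inhibition and higher numbers for weaker inhibition), compound 1 gives > 50000 nM, which is a limit of the assay and not a number. Compound 3 gives > 50000 nM, also a limit. Among the compounds with values here, compound 2 gives 5930 nM, the only number among the three. Compound 3 differs from compound 1 by fluoro in place of hydrogen on an aromatic carbon, and the step is a step that the two limits leave unreadable from compound 1 to compound 3, because both values sit at the limit of > 50000 nM in this assay, at which 2 of the 3 values shown sit. The difference between the two cores of compound 1 and compound 2 is not broken down here.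

Compound 4 `COc1cc(N/C=C\C(=O)c2cn(-c3ccccc3)nc2-c2ccc(F)cc2)cc(OC)c1OC` is not yet measured. It differs from compound 2 by fluoro in place of hydrogen on an aromatic carbon, the same change as from compound 1 to compound 3. Because a step that the two limits leave unreadable from compound 1 to compound 3 gives no readable size, the expectation for compound 4 rests on compound 2 alone. The change is therefore estimated to amount to a 1.1-fold lower number from compound 2 to compound 4 (0.03 log units; within the scatter). Compound 4 is expected to give about 5500 nM in this assay, likely between 2000 nM and 16000 nM.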

Compound 4, half-maximal inhibitory concentration: 4890 nM
Estimate against measurement, compound 4: 1.1-fold (0.05 log units) above; the measured number falls inside the stated range.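

In this assay, phenyl to 4-fluorophenyl on the core of compound 2 gives a 1.2-fold lower number from compound 2 to compound 4 (0.08 log units; within the scatter), so on this core the two values cannot be told apart. The same change on the core of compound 1 cannot be read, because compound 1 and compound 3 both stand at a limit of the assay and not at a number: the limit of > 50000 nM in this assay, at which 2 of the 4 values shown sit. This leaves one readable instance of the change, which shows nothing about whether its size carries from one core to another.

Open, from the compounds shown here alone, is whether an amine or a carboxylic acid in place of the fluoro would move the value on the core of compound 2 beyond the scatter. Also open, going by these compounds, is whether such a group on the core of compound 1 would give a number instead of a limit.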